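This account rests on a few compounds, and the source may have more. Where it says the series, first, only, none or still open, it means among the compounds named here.

Measured compounds:

compound 1 `COC(=O)[C@@]1(C)CCC=C2[C@@H]1CC[C@@H](C)[C@]2(C)Cc1c[nH]c2ccc(Br)cc12` — in a functional assay on A549 cells (Homo sapiens) for inhibition, read by sulforhodamine B assay, with a stated time of 48 h (on this read-out higher numbers stand for weaker inhibition of growth and lower numbers for stronger inhibition of growth), compound 1 gives 15000 nM
compound 2 `COC(=O)[C@@]1(C)CC[C@@H]2C3=C1CC[C@@H](C)[C@]3(C)C[C@@H]1c3cccc(C)c3N[C@H]21` — in this assay compound 2 gives 30000 nM

Within the data shown here, only two compounds have been measured here, and they cannot be separated from each other: the numbers of compound 2 and compound 1 lie within the usual scatter of repeated measurements, so neither can be called the more or less active of the pair. Among the measured compounds shown here, compound 2 therefore stands at a number that is, for practical purposes, the same as that of its only neighbour.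

The next compound, compound 3 `COC(=O)[C@@]1(C)CC[C@@H]2C3=C1CC[C@@H](C)[C@]3(C)C[C@@H]1c3cccc(Cl)c3N[C@H]21`, keeps the core of compound 2 and differs from it in one place: chloro in place of methyl on an aromatic carbon. For the measured compounds named here, no measured pair shows what this exchange does in this assay, so nothing in the data points to a large movement in either direction. Compound 3 is expected to stay close to compound 2, with an estimated step of a 1.2-fold lower number from compound 2 to compound 3 (0.08 log units; within the scatter) that does not clearly leave the scatter. The estimate for compound 3 in this assay is 25000 nM, within a range from 8000 nM to 80000 nM.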

Compound 3, concentration for 50% growth inhibition: 54000 nM
Estimate against measurement, compound 3: 2.2-fold (0.33 log units) below; low and high end bracket the measured number.
By their numbers in this assay, from the lowest: compounds 1, 2 and 3 (each within the scatter of the next, the first and the last beyond it).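

In this assay, among these compounds, the exchange of methyl for chloro on this aromatic carbon, ortho to a fused ring and meta to a fused ring, gives a 1.8-fold higher number from compound 2 to compound 3 (0.26 log units; within the scatter) and is the first measured change at this place. It shows that this one exchange, with one heavy atom leaving and one entering and the rest of the core unchanged, does not separate compound 2 from compound 3, so neither can be called the more active of the two. No measurement at hand offers an explanation for this result.

On these data alone, whether a methoxy group, an amine, a nitrile or a carboxylic acid on this same carbon would give a number beyond the scatter from compound 2 remains open, as does the outcome with plain hydrogen there. The compounds shown also leave open whether chloro in place of methyl would give a similar step on another aromatic carbon of the ring or on a different core, as this single pair is the only one that carries the exchange.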